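The source may hold more compounds than are shown below. What is called first, only, known or untested is meant among the compounds shown, and "the series" means these compounds.

Working notes on the series. Going by the values given here, compound 1 `COc1ccc(N2C(=O)NC3(CSC4=C3C(=O)c3ncccc3C4=O)C2=O)cc1` gives 2 nM in a functional assay on HT-29 cells (Homo sapiens) for antiproliferative activity, read by MTT assay, with a stated time of 96 h; on this read-out higher numbers stand for weaker inhibition and lower numbers for stronger inhibition; this is the lowest of the two numbers so far. Compound 2 `Cc1ccc(N2NC(=O)NC3(CSC4=C3C(=O)c3ncccc3C4=O)C2=O)cc1` gives 200 nM in this assay, a higher number, beyond the scatter. Compound 3 `O=C1C2=C(C(=O)c3ncccc31)C1(CS2)NC(=O)N(c2ccncc2)C1=O` is the next entry, not yet measured. Relative to compound 1 the change is pyridin-4-yl in place of 4-methoxyphenyl on an amide-type nitrogen in a ring. Among the compounds with values here, no single-point step between measured compounds exists for comparison. A modest step toward a higher number is expected, a 4.0-fold higher number from compound 1 to compound 3 (0.60 log units; beyond the scatter), as the most likely outcome. Compound 3 is estimated at 8 nM, within 2 nM to 40 nM.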

Compound 3, half-maximal inhibitory concentration: 2 nM
For compound 3 the middle estimate is 4.0-fold (0.60 log units) above the measured one; the measured number falls inside the stated range.
By their numbers in this assay, from the lowest: compounds 1 and 3 (each within the scatter of the next); then compound 2.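

In this assay, pyridin-4-yl in place of 4-methoxyphenyl on the amide-type nitrogen in a ring gives no change at the digits printed from compound 1 to compound 3 (within the scatter). This position therefore holds its low number with either a six-membered aromatic ring of carbon only or one with a hetero atom, and the methoxy group is not required among these two compounds. No other data bear on this result.

Open, from the compounds shown here alone, is whether the position needs an aromatic ring at all. A piperidin-4-yl group, or a phenyl group carrying a carboxylic acid, would test how far this holds.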